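Swapping the 3-nitrophenyl Group for Benzothiophene

The source may hold more compounds than are shown below. What is called first, only, known or untested is meant among the compounds shown, and "the series" means these compounds.

The measured compounds:
- Compound 1, `O=C(NC(=S)N1CCc2c(OCCCCCOc3ccc(Cl)cc3)cccc21)c1cccc([N+](=O)[O-])c1`, gives 12100 nM in an ADME assay on Huh-7 cells (Homo sapiens) for cytotoxicity; on this read-out higher numbers stand for lower toxicity in this test and lower numbers for higher toxicity in this test.
- Compound 2, `O=C(NC(=S)N1CCc2c(OCCCCCOc3ccc(Cl)cc3)cccc21)C1CCCC1`, gives a result in this assay that is only a limit of the assay, > 50000 nM.
- Compound 3, `O=C(NC(=S)N1CCc2c(OCCCCCOc3ccc(Cl)cc3)cccc21)c1cccs1`, gives 10700 nM in this assay.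

Compound 1 has the highest of the two plain numbers, yet compound 3 sits so close that the two cannot be told apart: a 1.1-fold lower number from compound 1 to compound 3 (0.05 log units; within the scatter). Compound 2 stands apart because of the limit of > 50000 nM in this assay, at which 1 of the 3 values shown sits, and the step to it is an at least 4.1-fold higher number from compound 1 to compound 2 (0.61 log units; beyond the scatter).

Compound 4, `O=C(NC(=S)N1CCc2c(OCCCCCOc3ccc(Cl)cc3)cccc21)c1cc2ccccc2s1`, is not yet measured. It differs from compound 1 in one place: 1-benzothiophen-2-yl in place of 3-nitrophenyl on a carbonyl carbon.

Among the measured compounds shown here, two measured steps bear on this. Replacing 3-nitrophenyl with thiophen-2-yl left the number where it was, while replacing it with cyclopentyl gave an at least 4.1-fold higher number from compound 1 to compound 2 (0.61 log units; beyond the scatter). Since 1-benzothiophen-2-yl keeps an aromatic ring on the carbonyl carbon, as thiophen-2-yl does, little change is expected. The estimate for compound 4 is 10000 nM, between 4000 nM and 25000 nM, meaning an expected step of a 1.2-fold lower number from compound 1 to compound 4 (0.08 log units; within the scatter).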

Compound 4, half-maximal cytotoxic concentration: > 50000 nM
Compound 4 gave a limit, no number; the forecaster's own chance of this, stated with the estimate: 10%; middle value at least 5.0-fold (0.69 log units) away from the limit.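

Putting 1-benzothiophen-2-yl in place of thiophen-2-yl gives an at least 4.6-fold higher number from compound 3 to compound 4 (0.66 log units; beyond the scatter), and putting it in place of 3-nitrophenyl gives an at least 4.1-fold higher number from compound 1 to compound 4 (0.61 log units; beyond the scatter). In this assay, an aromatic ring on this carbonyl carbon therefore does not by itself keep the number low, and compound 4, whose result is a limit and not a number, joins compound 2, the cyclopentyl compound, at that limit: the limit of > 50000 nM in this assay, at which 2 of the 4 values shown sit. With both results being limits, the step between compound 2 and compound 4 cannot be read.

The compounds shown leave open whether the shift follows the added six-membered aromatic ring or needs the sulfur-containing ring as well. A naphthalen-2-yl group on this carbonyl carbon, which has two six-membered aromatic rings and no sulfur, would help to separate these two readings.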